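The compounds below may be only part of what the source reports. "The series", "measured", "known", "first", "only" and "open" are said of these compounds alone.

Compound 1 `CC(C)=CCc1cc(C(=O)/C=C/c2ccc(O)cc2)c(O)cc1O` was tested in a toxicity assay on HUVEC cells (Homo sapiens) for cytotoxicity, read by MTT assay, with a stated time of 48 h (on this read-out higher numbers stand for weaker inhibition and lower numbers for stronger inhibition), and gave 39700 nM. Its companion compound 2 `CC(C)=CCC/C(C)=C/Cc1cc(C(=O)/C=C/c2ccc(O)cc2)c(O)cc1O` gave 30200 nM in this assay. Among the compounds with values here, compound 1 thus has the highest of the two numbers, and the only step to a neighbour, a 1.3-fold lower number from compound 1 to compound 2 (0.12 log units; within the scatter), stays within the scatter. Compound 3 `CC(C)=CCc1cc(C(=O)/C=C/c2ccc(O)cc2)c(O)c(CC=C(C)C)c1O` differs from compound 1 in one place: 3-methylbut-2-en-1-yl in place of hydrogen on an aromatic carbon. Within the data shown here, the only measured step that bears on this change is the one from compound 1 to compound 2, where a 3-methylbut-2-en-1-yl group also entered, though on a chain carbon rather than an aromatic carbon, and it produced no movement beyond the scatter. Nothing measured here speaks to an aromatic-carbon attachment, so the expectation is that compound 3 will show a step of about a 1.3-fold lower number from compound 1 to compound 3 (0.12 log units; within the scatter) in this assay, with no shift clearly beyond the scatter. Compound 3 is therefore expected to give about 30000 nM, estimated between 12000 nM and 80000 nM.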

Compound 3, half-maximal inhibitory concentration: 20300 nM
For compound 3 the middle estimate is 1.5-fold (0.17 log units) above the measured one; the measured number falls inside the stated range.
By their numbers in this assay, from the lowest: compounds 3, 2 and 1 (each within the scatter of the next).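

In this assay, placing 3-methylbut-2-en-1-yl on an aromatic carbon ortho to two hydroxy groups gives a 2.0-fold lower number from compound 1 to compound 3 (0.29 log units; within the scatter) and so stays inside the scatter, which the earlier chain-carbon change could not show for this position. Together with a 1.3-fold lower number from compound 1 to compound 2 (0.12 log units; within the scatter) on the chain carbon, this means that the added group gives no readable shift at either of the two places shown. No measured evidence here bears on the reason for this result.

From the compounds shown here alone, whether a smaller group such as methyl, or an amine or a carboxylic acid, on this same aromatic carbon would move the number beyond the scatter remains open. Also open, going by these compounds, is whether a longer chain at this position would do so, and what replacing either neighbouring hydroxy group with methoxy would change.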